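Butyl to pentyl on the aryl urea: working notes

This account rests on a few compounds, and the source may have more. Where it says the series, first, only, none or still open, it means among the compounds named here.

Measured so far in an ADME assay on the whole organism with Oryza sativa as the target, tested at 0.1 uM; a higher number here means a weaker effect of the compound at the concentration tested, a lower number a stronger effect:
compound 1 `CCc1ccccc1NC(=O)N[C@H](C)c1ccccc1`: 101%
compound 2 `CC(C)c1ccccc1NC(=O)N[C@H](C)c1ccccc1`: 103%
compound 3 `CCCCc1ccc(NC(=O)N[C@H](C)c2ccccc2)cc1`: 100%

All three compounds share a urea linking a substituted aromatic ring to the same phenylethyl amine, and all three sit at the top of the read-out scale in this assay, so none of them shows an effect at the concentration tested. Compound 1 and compound 2 differ only by methyl in place of hydrogen on a saturated chain carbon bound to an aromatic carbon and a saturated chain carbon; the step is a number 2 percentage points higher from compound 1 to compound 2 (within the scatter). How the core of compound 3 differs from the core of compound 1 is not broken down here, but the values of compound 1 and compound 3 lie within the scatter of each other, as do those of compound 2 and compound 3.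

Compound 4 `CCCCCc1ccc(NC(=O)N[C@H](C)c2ccccc2)cc1` has not yet been measured. It differs from compound 3 by methyl in place of hydrogen on a saturated chain carbon, four bonds along the chain from an aromatic carbon. This is the same kind of change as that from compound 1 to compound 2, though around a different place: there the methyl entered on a saturated chain carbon bound to an aromatic carbon and a saturated chain carbon, here it enters on a saturated chain carbon, four bonds along the chain from an aromatic carbon. Within the data shown here, since the one measured instance of this kind of change, a number 2 percentage points higher from compound 1 to compound 2 (within the scatter), stayed within the scatter, and since every compound measured so far sits at the top of the scale, compound 4 is expected to show a step of no change at the digits printed from compound 3 to compound 4 (within the scatter), again within the scatter. Compound 4 is therefore estimated at 100%, with a likely range from 92% to 108%.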

Compound 4, a percentage reported as activity, at one concentration (the size of the read-out at that concentration, not a potency): 100%
Beside the measured number, compound 4's estimate shows no gap at the digits printed, and the stated range covers the measured number.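

In this assay, methyl in place of hydrogen on a saturated chain carbon, four bonds along the chain from an aromatic carbon, gives no change at the digits printed from compound 3 to compound 4 (within the scatter). Set beside the earlier instance of this change, the two steps do not differ beyond what repeat measurements would give: the same change on two cores in this assay, a number 2 percentage points higher (within the scatter) from compound 1 to compound 2 and no change at the digits printed (within the scatter) from compound 3 to compound 4, 2 percentage points apart, within the scatter of two such steps. Among these compounds, this shows only that the change leaves the read-out within the scatter on both cores, at two different places on the chain; with no effect visible for any of the four compounds at the concentration tested, it does not show that a real effect of the change carries from one core to another.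

Open, from the compounds shown here alone, is whether a longer chain than pentyl, or an amine or a carboxylic acid on the aromatic ring, would move the read-out away from this level. Also open, going by these compounds, is how the same change would behave on a core that shows a clear effect in this assay.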